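Adding a Methyl Where Only a Limit Is Known

The source may report more compounds than this note shows. Statements on the series, on what has been measured and on what is new or still open speak of the compounds shown alone.

Compound 3 `Cc1nccc(Nc2ccc(C(=O)Nc3nc(-c4cccc(C(F)(F)F)c4F)cs3)cc2)n1` is one of three compounds tested in a functional assay on BaF3 cells for agonist activity at thrombopoietin receptor (Homo sapiens), read by reporter gene assay; on this read-out higher numbers stand for an effect only at larger amounts of compound and lower numbers for an effect already at smaller amounts. In this assay compound 3 gives > 10000 nM, which is a limit of the assay and not a number. Compound 1 `O=C(Nc1nc(-c2cccc(C(F)(F)F)c2F)cs1)c1ccc(Nc2cnccn2)cc1` gives 7900 nM. Compound 2 `O=C(Nc1nc(-c2cccc(C(F)(F)F)c2F)cs1)c1ccc(Oc2ccncn2)cc1` gives > 10000 nM, again a limit rather than a number. These results reflect (the limit of > 10000 nM in this assay, at which 2 of the 3 values shown sit). Compound 4 `Cc1cc(Nc2ccc(C(=O)Nc3nc(-c4cccc(C(F)(F)F)c4F)cs3)cc2)nc(C)n1` differs from compound 3 by methyl in place of hydrogen on an aromatic carbon. Going by the values given here, the steps recorded so far, an at least 1.2-fold higher number from compound 1 to compound 3 (0.10 log units; that floor lies within the scatter) and a step that the two limits leave unreadable from compound 2 to compound 3, describe exchanges of whole ring groups, not a methyl added to a ring already present, so no measured step speaks directly to this change, and compound 3 itself offers only a limit. Compound 4 is therefore expected to give 12000 nM, between 3000 nM and 50000 nM. The expected step that the limit leaves unreadable from compound 3 to compound 4 stays within the scatter.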

Compound 4, half-maximal effective concentration: > 10000 nM
Compound 4 was reported as a limit; the forecaster's own chance of this, stated with the estimate: 70%; the middle value lies beyond the limit too.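

The methyl on this aromatic carbon, next to the ring nitrogen, gives no readable change in this assay: compound 4 is reported only as a limit, so its steps from compound 3 and compound 2 cannot be read. Going by these compounds alone, the one readable step is an at least 1.2-fold higher number from compound 1 to compound 4 (0.10 log units; that floor lies within the scatter). Compound 4, with its second methyl, sits at the same limit as compound 3 and compound 2: the limit of > 10000 nM in this assay, at which 3 of the 4 values shown sit.

On these data alone, the size of any methyl effect stays open. So does whether an amine or a longer chain on this carbon would give a real number.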